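Shortening the alkyne to a hydroxypropynyl sulfonamide

The source may report more compounds than this note shows. Statements on the series, on what has been measured and on what is new or still open speak of the compounds shown alone.

Compound 1 `CC(=O)Nc1nc(-c2cccc(NS(=O)(=O)c3cccc(Br)c3)c2)cs1`: 36%
Compound 2 `CC(=O)Nc1nc(-c2cccc(NS(=O)(=O)c3ccc(C#CC4CCCCC4)cc3)c2)cs1`: 1.2%
Compound 3 `CCCCCCC#Cc1cccc(S(=O)(=O)Nc2cccc(-c3csc(NC(C)=O)n3)c2)c1`: < 1%

In a functional assay on A-375 cells (Homo sapiens) for antiproliferative activity, read by trypan blue exclusion, with a stated time of 48 h, tested at 10 uM (a lower number here means a stronger effect, a higher number a weaker effect of the compound at the concentration tested), compound 3 gives only a limit, < 1%, with no number behind it (the limit of < 1% in this assay, at which 1 of the 3 values shown sits). Compound 4 `CC(=O)Nc1nc(-c2cccc(NS(=O)(=O)c3cccc(C#CCO)c3)c2)cs1` differs from compound 3 by hydroxy in place of pentyl on a saturated chain carbon bound to a triple-bonded carbon. Among the measured compounds shown here, the one measured step that bears on this change is a number at least 35 percentage points lower from compound 1 to compound 3 (beyond the scatter), where the oct-1-yn-1-yl group carried compound 3 to the limit. Compound 4 keeps the alkyne but loses the pentyl and gains a hydroxy, and compound 2, with a different alkyne, sits at 1.2%. Compound 4 is therefore expected to lose some of that effect, with a step of a number at least 24 percentage points higher from compound 3 to compound 4 (beyond the scatter). Compound 4 is estimated at 25%, in the range 5% to 50%.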

Compound 4, a percentage reported as activity, at one concentration (the size of the read-out at that concentration, not a potency): 45.3%
Estimate against measurement, compound 4: 20.3 percentage points below; the measured number falls inside the stated range.
By their numbers in this assay, from the lowest: compound 2; then compounds 1 and 4 (each within the scatter of the next). At a limit, below all of these: compound 3.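

In this assay, the triple bond alone does not carry the effect: hydroxy in place of pentyl on a saturated chain carbon bound to a triple-bonded carbon gives a number at least 44.3 percentage points higher from compound 3 to compound 4 (beyond the scatter). The value of compound 3 is a limit, and this step is read against it: the limit of < 1% in this assay, at which 1 of the 4 values shown sits. With 3-hydroxyprop-1-yn-1-yl in place of bromo, the result is a number 9.3 percentage points higher from compound 1 to compound 4 (within the scatter), so among compounds 1, 3 and 4 the gain goes with oct-1-yn-1-yl.

Whether the shorter chain or the hydroxy accounts for the change remains open. A short alkyl chain without the hydroxy, or an amine in its place, would separate the two.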